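The source may report more compounds than this note shows. Statements on the series, on what has been measured and on what is new or still open speak of the compounds shown alone.

In a functional assay on MCF7 cells (Homo sapiens) for cytotoxicity, read by MTT assay, with a stated time of 72 h (on this read-out higher numbers stand for weaker inhibition and lower numbers for stronger inhibition), two compounds sharing one core have been measured so far. Compound 1 `CN(C)CCCCCn1c2c(c3ccccc31)C(=O)c1c[n+]([O-])c3ccccc3c1C2=O` gives 200 nM, and compound 2 `O=C1c2c[n+]([O-])c3ccccc3c2C(=O)c2c1c1ccccc1n2Cc1cn(C[C@@H](O)CO)nn1` gives 600 nM, the higher of the two numbers and so the weaker inhibition. Compound 3 `CN1CCN(CCCCCn2c3c(c4ccccc42)C(=O)c2c[n+]([O-])c4ccccc4c2C3=O)CC1` keeps that core and differs from compound 2 only in the group on a saturated chain carbon bound to an aromatic nitrogen: 4-(4-methylpiperazin-1-yl)butyl in place of 1-(2,3-dihydroxypropyl)-1H-1,2,3-triazol-4-yl on a saturated chain carbon bound to an aromatic nitrogen. Thus 4-(4-methylpiperazin-1-yl)butyl replaces 1-(2,3-dihydroxypropyl)-1H-1,2,3-triazol-4-yl. Among the compounds with values here, one measured step bears on this change: a 3.0-fold higher number from compound 1 to compound 2 (0.48 log units; beyond the scatter). In that step, the same triazole group replaced the 4-(dimethylamino)butyl of compound 1. The group entering compound 3 is likewise a butyl group carrying an amine, so compound 3 resembles compound 1 more closely than compound 2. A change of similar modest size is therefore expected, this time towards a lower number, although a single step is thin evidence. The expected change is a 2.7-fold lower number from compound 2 to compound 3 (0.44 log units; beyond the scatter). The estimate for compound 3 is 220 nM, within a range of 80 nM to 600 nM.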

Compound 3, half-maximal inhibitory concentration: 1260 nM
Estimate against measurement, compound 3: 5.7-fold (0.76 log units) below; measured number above the stated range.
By their numbers in this assay, from the lowest: compound 1; then compound 2; then compound 3.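

In this assay, a butyl chain ending in an amine does not by itself give a low number: 4-(4-methylpiperazin-1-yl)butyl in place of the triazole group gives a 2.1-fold higher number from compound 2 to compound 3 (0.32 log units; beyond the scatter), so compound 3 is the weakest of the three. The amine on the chain matters, since 4-methylpiperazin-1-yl in place of dimethylamino, five bonds along the chain from the aromatic nitrogen, gives a 6.3-fold higher number from compound 1 to compound 3 (0.80 log units; beyond the scatter), and the two amine-bearing compounds therefore fall on either side of compound 2, which has a triazole group instead. No supporting measurement is available to explain this order.

Still open, as far as these compounds go, is whether the rise from compound 1 to compound 3 follows the ring or the second nitrogen within it, which a piperidine or a morpholine on the same chain could help to separate. From the compounds shown here alone, the role of chain length is also open, since all the amines here sit on one chain length, and a propyl or hexyl chain ending in dimethylamino would test how much that length counts.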